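The compounds below may be only part of what the source reports. "The series", "measured", "known", "first", "only" and "open" are said of these compounds alone.

Compound 1 `O=C(CN1CCN(C(=O)c2cccc(Cl)c2)CC1)N1CCN(CCCc2c[nH]c3ccc(F)cc23)CC1` gives 59800 nM.
Compound 2 `COc1cccc(C(=O)N2CCN(CC(=O)N3CCN(CCCc4c[nH]c5ccc(F)cc45)CC3)CC2)c1` gives 79400 nM.
Compound 3 `COc1ccc2[nH]cc(CCCN3CCN(C(=O)CN4CCN(C(=O)c5cccc(Cl)c5)CC4)CC3)c2c1` gives only a limit of the assay, > 200000 nM.

All three were run in an ADME assay on SH-SY5Y cells (Homo sapiens) for cytotoxicity, read by MTT assay, with a stated time of 72 h; a higher number here means a weaker inhibitor, a lower number a stronger inhibitor. Compound 1 and compound 2 share a core and differ by methoxy in place of chloro on an aromatic carbon; the step is a 1.3-fold higher number from compound 1 to compound 2 (0.12 log units; within the scatter). Compound 3 carries a different core, and the difference from compound 1 is methoxy in place of fluoro on an aromatic carbon; the step is an at least 3.3-fold higher number from compound 1 to compound 3 (0.52 log units; beyond the scatter). For compound 3 the number reported is the limit of > 200000 nM in this assay, at which 1 of the 3 values shown sits, so the true position of compound 3 is not known beyond that limit.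

Compound 4 `COc1cccc(C(=O)N2CCN(CC(=O)N3CCN(CCCc4c[nH]c5ccc(OC)cc45)CC3)CC2)c1` has not yet been measured. It differs from compound 3 by methoxy in place of chloro on an aromatic carbon, the same change that separates compound 2 from compound 1, and it sits in the same place on the ring in both pairs. In this assay compound 4 is therefore expected to give 300000 nM, with a range estimated from 150000 nM to 700000 nM. The step that this estimate means, a step that the limit leaves unreadable from compound 3 to compound 4, is expected to be small because the same change gave a 1.3-fold higher number from compound 1 to compound 2 (0.12 log units; within the scatter) when made on the core of compound 1. Since the starting point is already a limit, the expectation is that compound 4 will most likely also be reported as a limit rather than a number.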

Compound 4, half-maximal inhibitory concentration: > 200000 nM
Compound 4 was reported as a limit; the forecaster's own chance of this, stated with the estimate: 85%; the middle value does not contradict the limit.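

In this assay, methoxy in place of fluoro gives an at least 2.5-fold higher number from compound 2 to compound 4 (0.40 log units; beyond the scatter), so the change points the same way on the core carrying the 3-methoxyphenyl group as on the core carrying the 3-chlorophenyl group, and the comparison of its size goes no further than this: the same change on two cores in this assay, an at least 3.3-fold higher number (0.52 log units; beyond the scatter) from compound 1 to compound 3 and an at least 2.5-fold higher number (0.40 log units; beyond the scatter) from compound 2 to compound 4; the limit leaves it open whether they differ Compound 4 is reported only as a limit of the assay, > 200000 nM, the same kind of result as for compound 3: the limit of > 200000 nM in this assay, at which 2 of the 4 values shown sit. The step from compound 3 to compound 4 cannot be read, so the exchange of 3-chlorophenyl for 3-methoxyphenyl, which gave a 1.3-fold higher number from compound 1 to compound 2 (0.12 log units; within the scatter), is not shown either to carry over to the methoxy-bearing core or to fail to do so.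

The compounds shown leave open where compound 3 and compound 4 truly lie, and therefore whether the methoxy for fluoro change has the same size on both cores. They also leave open what a nitrile or a trifluoromethyl in place of the chloro of the 3-chlorophenyl group, or a hydroxyl in place of the fluoro, would give in this assay.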